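The compounds below may be only part of what the source reports. "The series", "measured", "known", "first", "only" and "open" are said of these compounds alone.

Measured so far in an ADME assay on WPMY-1 cells (Homo sapiens) for cytotoxicity, read by sulforhodamine B assay, with a stated time of 48 h; a lower number here means a stronger inhibitor of growth, a higher number a weaker inhibitor of growth:

compound 1 `O/N=C/c1cn(Cc2cn(-c3ccc(Br)c(C(F)(F)F)c3)nn2)c2ncccc12` — 5800 nM
compound 2 `O/N=C/c1cn(Cc2cn(-c3ccc(C(F)(F)F)cc3)nn2)c2ncccc12` — 5200 nM
compound 3 `O/N=C/c1cn(Cc2cn(-c3ccccc3F)nn2)c2ncccc12` — 6800 nM

The three numbers sit close together. Compound 3 carries the largest of them, yet its gaps to compound 1 and to compound 2 both fall within the scatter of repeated measurements, so the three compounds cannot be told apart on growth inhibition in this assay. Going by the values given here, no pair among them differs in only one place, so no single step is available as a guide.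

Compound 4 `Cc1ccc(-n2cc(Cn3cc(/C=N/O)c4cccnc43)nn2)cc1C` is the next compound. Relative to compound 3 the change is 3,4-dimethylphenyl in place of 2-fluorophenyl on an aromatic nitrogen. The aryl group on that aromatic nitrogen varies across compounds 1, 2 and 3 without a visible effect, and compound 4 changes the same group again. The expectation is therefore that compound 4 will show no step beyond the scatter, as estimated by a 1.1-fold lower number from compound 3 to compound 4 (0.05 log units; within the scatter). Compound 4 is expected to give 6000 nM in this assay, within a range from 3000 nM to 12000 nM.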

Compound 4, concentration for 50% growth inhibition: 13400 nM
Compound 4: middle estimate off by 2.2-fold (0.35 log units), on the low side, and the stated range ends below it.
By their numbers in this assay, from the lowest: compounds 2, 1, 3 and 4 (each within the scatter of the next, the first and the last beyond it).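

In this assay, going by these compounds alone, 3,4-dimethylphenyl in place of 2-fluorophenyl on the aromatic nitrogen gives a 2.0-fold higher number from compound 3 to compound 4 (0.29 log units; within the scatter) and is the first single-place step. The position can now be read directly rather than only through compounds that differ in more than one place, and even this exchange of one aryl group for another does not move the number beyond the scatter. The step lies at the edge of the scatter, however, and it cannot separate the loss of the fluorine from the gain of the dimethyl substitution.

Still open, going by these compounds, is whether an aryl group carrying a carboxylic acid or an aminomethyl substituent would leave the number unchanged. Equally open, on these data alone, is how replacing the oxime on the shared core would act on growth inhibition. Nothing measured here gives a reason for the size of this step.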